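A few compounds are considered here, and "the series" means these few. Any claim that something is new, unique, unknown or untested is made for them only; others in the source may bear on it.

Measured so far:
compound 1 `O=C(CI)NCCCCCCCCNc1ncnc2c1ncn2[C@@H]1O[C@H](COP(=O)(O)OP(=O)(O)OP(=O)(O)O)[C@@H](O)[C@H]1O` — 35%
compound 2 `Nc1ncnc2c1nc(NCCCCNC(=O)CI)n2[C@@H]1O[C@H](COP(=O)(O)OP(=O)(O)OP(=O)(O)O)[C@@H](O)[C@H]1O` — 0%
compound 3 `O=C(CI)NCCCCCCC(=O)NCCCCCCNc1ncnc2c1ncn2[C@@H]1O[C@H](COP(=O)(O)OP(=O)(O)OP(=O)(O)O)[C@@H](O)[C@H]1O` — 0%

In an assay on isolated protein for inhibition of hexokinase-1 (Rattus norvegicus), with a stated time of 6 h, tested at 10 mM (on this read-out lower numbers stand for less inhibition and higher numbers for more inhibition at the one concentration tested (going by the name of the read-out)), compound 3 gives 0%, level with compound 2 at the digits shown, and together these two are the lowest of the three numbers. Compound 1 stands apart from compound 3 by a gap beyond the scatter, in the direction of more inhibition.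

Compound 4 `O=C(CI)NCCCC(=O)NCCCCCCNc1ncnc2c1ncn2[C@@H]1O[C@H](COP(=O)(O)OP(=O)(O)OP(=O)(O)O)[C@@H](O)[C@H]1O` differs from compound 3 in one place: ((iodomethyl)carbonyl)amino in place of 3-(((iodomethyl)carbonyl)amino)propyl on a saturated chain carbon, three bonds along the chain from a carbonyl carbon.

Going by the values given here, no measured step of this kind exists among the three compounds. The step from compound 3 to compound 4 is expected to stay within the scatter, with no movement in either direction beyond it, as a number 3 percentage points higher from compound 3 to compound 4 (within the scatter). Compound 4 is therefore estimated at 3%, between 0% and 15%.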

Compound 4, a percentage reported as inhibition, at one concentration (the size of the read-out at that concentration, not a potency): 0%
The estimate for compound 4 lay 3 percentage points above the measured number; measured number inside the range.
By their numbers in this assay, from the lowest: compounds 2, 3 and 4 (each within the scatter of the next); then compound 1.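

In this assay, putting ((iodomethyl)carbonyl)amino in place of 3-(((iodomethyl)carbonyl)amino)propyl on this saturated chain carbon shows no effect on the read-out, with no change at the digits printed from compound 3 to compound 4 (within the scatter), so this shorter chain does not bring inhibition back. The group of 11 heavy atoms in place of the group of 7 heavy atoms goes with a large loss, a number 35 percentage points lower from compound 1 to compound 4 (beyond the scatter). Nothing at hand explains either step.

On these data alone, whether the gap to compound 1 follows the amide within the chain or the chain's length stays open. So does whether an unbroken hydrocarbon chain or a chloroacetyl end group at this position would restore inhibition.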